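Aryl variation on a legumain nitrile series

The compounds below may be only part of what the source reports. "The series", "measured", "known", "first", "only" and "open" are said of these compounds alone.

compound 1 `C[C@H](C(=O)N[C@H](C#N)CC(N)=O)N(Cc1ccc(-c2cc(F)cc(F)c2)cc1)S(C)(=O)=O`: 9250 nM
compound 2 `C[C@@H](C(=O)N[C@H](C#N)CC(N)=O)N(Cc1ccc(-c2cc(F)cc(F)c2)cc1)S(C)(=O)=O`: 1360 nM
compound 3 `C[C@@H](C(=O)N[C@H](C#N)CC(N)=O)N(Cc1ccc(-c2cccc(F)c2)cc1)S(=O)(=O)c1ccccc1`: > 10000 nM

In an assay on isolated protein for inhibition of legumain (Homo sapiens), with stated times of 2 min and 60 min (on this read-out higher numbers stand for weaker inhibition and lower numbers for stronger inhibition), compound 1 gives 9250 nM and stands highest of the two numbers. Compound 2 gives 1360 nM. For compound 3 the read-out is only a limit, > 10000 nM. Within the data shown here, the single measured step, a 6.8-fold lower number from compound 1 to compound 2 (0.83 log units; beyond the scatter), rests on configuration alone, as the fact that compounds 1 and 2 differ only in the configuration as drawn shows, and says nothing about the aryl group.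

Compound 4 `C[C@H](C(=O)N[C@H](C#N)CC(N)=O)N(Cc1ccc(-c2cccc(C(F)(F)F)c2)cc1)S(C)(=O)=O` keeps the configuration of compound 1 and differs by 3-(trifluoromethyl)phenyl in place of 3,5-difluorophenyl on an aromatic carbon. Among the measured compounds shown here, no measured step touches this position; compound 3 carries another aryl group but also another sulfonyl group and sits at the limit of > 10000 nM in this assay, at which 1 of the 3 values shown sits, so it cannot anchor the change. Compound 4 is therefore expected to give about 9000 nM, within 3000 nM to 25000 nM. The expected step of a 1.0-fold lower number from compound 1 to compound 4 (0.01 log units; within the scatter) is estimated to stay within the scatter.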

Compound 4, half-maximal inhibitory concentration: > 10000 nM
Compound 4 was reported as a limit; the forecaster's own chance of this, stated with the estimate: 35%; at least 1.1-fold (0.04 log units) between middle value and limit.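

In this assay compound 4 gives > 10000 nM, which is a limit and not a number. Among these compounds, with the sulfonyl group and configuration held, 3-(trifluoromethyl)phenyl in place of 3,5-difluorophenyl gives the first direct reading at this aromatic carbon, an at least 1.0-fold higher number from compound 1 to compound 4 (0.03 log units; that floor lies within the scatter), so the two aryl groups are not separated. Limits now mark a good part of this small set: the limit of > 10000 nM in this assay, at which 2 of the 4 values shown sit.

Open, going by these compounds, is how 3-(trifluoromethyl)phenyl reads on the configuration of compound 2, and whether an amine or a carboxylic acid on this aromatic ring moves the number.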